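The compounds below may be only part of what the source reports. "The series", "measured", "known", "first", "only" and "open" are said of these compounds alone.

Of the compounds shown here, three have so far been tested in a functional assay (Cavia porcellus) for antagonist activity at Serotonin 3 (5-HT3) receptor (Homo sapiens); on this read-out higher numbers stand for weaker inhibition and lower numbers for stronger inhibition. Compound 1 `O=C1N(c2cccc(Br)c2)CCN1C1CN2CCC1CC2` gives 38.3 nM. Compound 2 `Cc1[nH]cnc1CN1CCN(c2cccc(Cl)c2)C1=O` gives 12 nM, and compound 3 `Cc1[nH]cnc1CN1CCN(c2cccc(Br)c2)C1=O` gives 10.4 nM. Among these three numbers compound 2 holds the second highest place; the step of a 1.2-fold lower number from compound 2 to compound 3 (0.06 log units; within the scatter), a swap of bromo for chloro on an aromatic carbon, is within the scatter, whereas compound 1 lies furthest away, with a number higher by an amount beyond the scatter.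

Compound 4 `Cc1[nH]cnc1CN1CCN(c2cc(Cl)cc(Cl)c2)C1=O` has not yet been measured. It differs from compound 2 by chloro in place of hydrogen on an aromatic carbon. Among the compounds with values here, no measured step covers this kind of change: the only recorded step exchanges one halogen for another at the same place and says nothing about adding a second halogen. The numbers of compound 2 and compound 3 show that two different halogens at that place give numbers within the scatter of each other, so a second chloro is expected to move the number little. Compound 4 is therefore estimated at 12 nM, with a range from 4 nM to 36 nM. This estimate means an expected step of no change at the digits printed from compound 2 to compound 4 (within the scatter), no more than the scatter allows.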

Compound 4, antagonist equilibrium constant: 5.62 nM
Estimate against measurement, compound 4: 2.1-fold (0.33 log units) above; measured number inside the range.
By their numbers in this assay, from the lowest: compounds 4, 3 and 2 (each within the scatter of the next, the first and the last beyond it); then compound 1.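

In this assay, chloro in place of hydrogen on an aromatic carbon, meta to a chloro group, gives a 2.1-fold lower number from compound 2 to compound 4 (0.33 log units; beyond the scatter) as a modest change. The earlier step only exchanged one halogen for another at a single place on this ring, and it stayed within the scatter. This new step shows that adding a halogen at a place that held hydrogen can lower the number by more than the scatter, so this position is not indifferent to substitution, although no measurement offered here explains the change.

As far as these compounds go, whether a methoxy group or an amine at this position would also lower the number remains open. So does whether bromo would match chloro here, and whether the same addition would have a similar effect on the core of compound 1.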